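Compound 1 to compound 3: methyl on the amide-type nitrogen

This account rests on a few compounds, and the source may have more. Where it says the series, first, only, none or still open, it means among the compounds named here.

Compound 1 `CO[C@@H]1[C@H](OC(=O)NC(=O)CCl)CO[C@]2(COC(C)(C)O2)[C@@]1(O)C1(C)CO1` gives 57000 nM in a functional assay on cells (Endothelial cell, Sus scrofa) for antiproliferative activity; on this read-out higher numbers stand for weaker inhibition and lower numbers for stronger inhibition
Compound 2 `CO[C@@H]1[C@H](OC(=O)NC(=O)CCl)CO[C@]2(COC(C)(C)O2)[C@@]1(O)C1OC1CC(C)C` gives 124000 nM; 178000 nM (2 entries) in this assay

On these numbers, compound 1 at 57000 nM sits lower, and so inhibits more strongly, than both entries of compound 2 (the several entries of compound 2 in this assay, 124000 nM; 178000 nM (2 entries)). One further entry for compound 1 carries no single number.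

Compound 3 `CNC(=O)O[C@@H]1CO[C@]2(COC(C)(C)O2)[C@@](O)(C2(C)CO2)[C@@H]1OC` has not yet been measured. It keeps the core of compound 1 and changes one group, with methyl in place of (chloromethyl)carbonyl on an amide-type nitrogen.

Among the compounds with values here, no measured pair covers this change. A moderate step toward weaker inhibition is expected in this assay, estimated as a 3.0-fold higher number from compound 1 to compound 3 (0.47 log units; beyond the scatter). That expectation rests only on the value of compound 1, 57000 nM, and on this one change. Compound 3 is estimated at 170000 nM, with an expected range from 70000 nM to 500000 nM.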

Compound 3, half-maximal inhibitory concentration: 195000 nM
Beside the measured number, compound 3's estimate is 1.1-fold (0.06 log units) below it, within the range that was stated.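

In this assay, within the data shown here, methyl in place of (chloromethyl)carbonyl on the amide-type nitrogen gives a 3.4-fold higher number from compound 1 to compound 3 (0.53 log units; beyond the scatter) as the first measured change at this position. Inhibition is therefore weaker with methyl here than with (chloromethyl)carbonyl, yet compound 3 still gives a numerical read-out without the chlorine or the second carbonyl. No measured property of either group accompanies this step, and the data on the compound changed elsewhere in the structure do not bear on it.

With only these two groups compared at this nitrogen, the contributions of the chlorine and the carbonyl remain unseparated, and an acetyl group, which keeps the carbonyl without the chlorine, would divide them. Also open, going by these compounds, is how an unsubstituted nitrogen or a longer chain such as propyl would read out at this position.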